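Swapping fluorine for chlorine on a benzimidazole ring

This account rests on a few compounds, and the source may have more. Where it says the series, first, only, none or still open, it means among the compounds named here.

Measured compounds:
- compound 1, `CN1CCN(CCCN(c2nc3cc(F)c(C(F)(F)F)cc3[nH]2)[C@@H]2CC[C@]3(c4ccc(C#N)cc4)C[C@H]23)CC1`, 8.6 nM
- compound 2, `CN1CCN(CCCN(c2nc3cc(F)c(F)cc3[nH]2)[C@@H]2CC[C@]3(c4cccc(C#N)c4)C[C@@H]3C2)CC1`, 8.4 nM

Both compounds were tested in an assay on isolated protein for binding affinity to melanin-concentrating hormone receptor 1 (Homo sapiens); a higher number here means a weaker inhibitor, a lower number a stronger inhibitor. Compound 1 gives 8.6 nM. Compound 2 gives 8.4 nM, the lower of the two numbers, yet its gap to compound 1 lies within the usual scatter, so the two cannot be told apart on these figures alone.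

Compound 3, `CN1CCN(CCCN(c2nc3cc(Cl)c(Cl)cc3[nH]2)[C@@H]2CC[C@]3(c4cccc(C#N)c4)C[C@@H]3C2)CC1`, has not yet been measured. It differs from compound 2 in one place: 5,6-dichloro-1H-benzimidazol-2-yl in place of 5,6-difluoro-1H-benzimidazol-2-yl on an amine nitrogen. Among the measured compounds shown here, no measured pair shows the effect of this particular exchange, so there is no step to lean on. The expectation is therefore a step in this assay that stays within the scatter, with no clear direction, which is what a 1.1-fold lower number from compound 2 to compound 3 (0.02 log units; within the scatter) expresses. On that basis compound 3 is expected to give about 8 nM, most likely between 3 nM and 25 nM.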

Compound 3, inhibition constant: 2.2 nM
Compound 3: the middle estimate sits 3.6-fold (0.56 log units) above what was measured, outside the stated range (below it).
By their numbers in this assay, from the lowest: compound 3; then compounds 2 and 1 (each within the scatter of the next).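

In this assay, 5,6-dichloro-1H-benzimidazol-2-yl in place of 5,6-difluoro-1H-benzimidazol-2-yl gives a 3.8-fold lower number from compound 2 to compound 3 (0.58 log units; beyond the scatter), so the group on this amine nitrogen is sensitive to which halogen its ring carries. Compound 1 and compound 2 differ in more than one place, so no single exchange could be read from them, whereas here only the two halogens change. Nothing available here explains why the two chlorines give the lower number.

As far as these compounds go, with only fluorine and chlorine compared, it stays open whether two bromines or two methyl groups in their place would give a lower or a higher number. From the compounds shown here alone, it also stays open whether a single chlorine would be enough, and whether the same exchange would hold on the core of compound 1.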